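The compounds below may be only part of what the source reports. "The series", "measured", "known", "first", "only" and "open" are said of these compounds alone.

Measured compounds:
compound 1 `C=CCc1ccc(OCc2cn(-c3ccc(C#N)cc3)nn2)c(O)c1` — 62.5%
compound 2 `C=CCc1ccc(OCc2cn(-c3ccccc3CO)nn2)c(O)c1` — 87.1%

In a functional assay on SK-N-SH cells (Homo sapiens) for inhibition, read by MTT assay, with a stated time of 72 h, tested at 50 uM (a lower number here means less inhibition of growth, a higher number more inhibition of growth at the concentration tested), compound 1 gives 62.5%, the lower of the two numbers recorded. Compound 2 gives 87.1%. Within the data shown here, the only measured step is a number 24.6 percentage points higher from compound 1 to compound 2 (beyond the scatter), which changes the group on the aromatic nitrogen, not the group that compound 3 alters. Compound 3 `C=CCc1ccc(OCc2cn(-c3ccc(C(=O)c4ccccc4)cc3)nn2)c(O)c1` differs from compound 1 by benzoyl in place of cyano on an aromatic carbon. Among the measured compounds shown here, since no measured step touches this position, the expected direction rests on little. The step from compound 1 to compound 3 is estimated at a number 3.5 percentage points higher from compound 1 to compound 3 (within the scatter), within the scatter. Compound 3 is therefore expected to give about 66%, between 42% and 88%.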

Compound 3, percent growth inhibition at one concentration: 58.1%
Compound 3: middle estimate off by 7.9 percentage points, on the high side; the measured number falls inside the stated range.
By their numbers in this assay, from the lowest: compounds 3 and 1 (each within the scatter of the next); then compound 2.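

In this assay, benzoyl in place of cyano gives a number 4.4 percentage points lower from compound 1 to compound 3 (within the scatter), so this assay does not separate the two groups. The position on the aromatic carbon therefore accepts benzoyl, which brings an additional six-membered aromatic ring, with a step no larger than the scatter. No measurement at hand offers an explanation for this result. As far as these compounds go, what an amine or a carboxylic acid on this carbon would give remains open. So does whether a group other than cyano or benzoyl here could reach the number of compound 2, 87.1%.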